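The compounds below may be only part of what the source reports. "The series", "measured", "known", "first", "only" and "open" are said of these compounds alone.

Compound 1 (`O=C(Nc1ccc(Sc2nc3ccccc3s2)c(Cl)c1)c1cc(Br)cc(Br)c1`) and compound 2 (`O=C(Nc1ccc(Sc2nc3ccccc3s2)cc1)c1cc(Br)cc(Br)c1`) have both been tested in an ADME assay on HEK293 cells (Homo sapiens) for cytotoxicity, read by reporter gene assay and resazurin assay, with a stated time of 48 h; a higher number here means that more compound is tolerated, a lower number that less compound is tolerated. Compound 1 gives > 100000 nM, which is a limit of the assay and not a number. Compound 2 gives > 100000 nM, again only a limit. Compound 2 therefore has no exact figure and stands at the limit of > 100000 nM in this assay, at which 2 of the 2 values shown sit. Going by the values given here, the one measured step, a step that the two limits leave unreadable from compound 1 to compound 2, puts hydrogen in place of chloro on an aromatic carbon, and it offers no size to carry forward.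

Compound 3 (`COc1c(Br)cccc1C(=O)Nc1ccc(Sc2nc3ccccc3s2)cc1`) has yet to be measured in this assay. It keeps the shared core and changes only the group on the carbonyl carbon: a group of 9 heavy atoms (7 carbon, 1 oxygen, 1 bromine; one six-membered aromatic ring of carbon only) in place of a group of 8 heavy atoms (6 carbon, 2 bromine; one six-membered aromatic ring of carbon only), on a carbonyl carbon. Among the compounds with values here, no measured step involves a change at this place, so the only guide is that both tested compounds sit at the same limit. With nothing pointing to a change in either direction, the expected step is a number no higher from compound 2 to compound 3 (the limit leaves the size open), which means none beyond the usual scatter. For compound 3 the estimate is 100000 nM, with an expected range from 40000 nM to 200000 nM, and the assay may well report only a limit again.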

Compound 3, half-maximal cytotoxic concentration: > 100000 nM
Compound 3: only a limit was reported (the forecaster's own chance of this, stated with the estimate: 70%); the middle value sits exactly at the limit.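

In this assay compound 3 gives > 100000 nM, a limit of the assay and not a number. Compound 2 also sits at a limit, so no step can be read between compound 2 and compound 3. Compounds 1, 2 and 3 all stop at one limit, leaving open how much of each compound the cells actually tolerate.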